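Swapping the Vinyl on the Sulfonyl Sulfur for Aminoethyl

The compounds below may be only part of what the source reports. "The series", "measured", "known", "first", "only" and "open" are said of these compounds alone.

Of the compounds shown here, two have been measured in an assay on CHO cells for binding affinity to transient receptor potential cation channel subfamily V member 1 (Rattus norvegicus); on this read-out lower numbers stand for stronger inhibition and higher numbers for weaker inhibition. Compound 1 `CC(C)(C)c1ccc(C/N=C(\S)NCc2ccc(CNS(C)(=O)=O)cc2)cc1` gives 6120 nM. Within the data shown here, compound 2 `C=CS(=O)(=O)Nc1ccc(CN/C(S)=N/Cc2ccc(C(C)(C)C)cc2)cc1` gives 231 nM, the lowest of the two numbers, set apart by the single measured step of a 26-fold lower number from compound 1 to compound 2 (1.42 log units; beyond the scatter). Compound 3 `CC(C)(C)c1ccc(C/N=C(\S)NCc2ccc(NS(=O)(=O)CCN)cc2)cc1` differs from compound 2 in one place: 2-aminoethyl in place of vinyl on a sulfonyl sulfur. Among the measured compounds shown here, only the step from compound 1 to compound 2 is available to bear on this change, and it was large, yet it altered both the link to the ring and the group on the sulfonyl sulfur at once, so it speaks to the present change only loosely. Compound 3 is expected to show a higher number than compound 2, meaning weaker binding, with an estimated step of a 6.5-fold higher number from compound 2 to compound 3 (0.81 log units; beyond the scatter). The estimate for compound 3 in this assay is 1500 nM, within a range from 400 nM to 6000 nM.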

Compound 3, inhibition constant: 4640 nM
Compound 3: the middle estimate sits 3.1-fold (0.49 log units) below what was measured; low and high end bracket the measured number.
By their numbers in this assay, from the lowest: compound 2; then compounds 3 and 1 (each within the scatter of the next).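

In this assay, the group on the sulfonyl sulfur now stands alone as the change, and it matters on its own: 2-aminoethyl in place of vinyl gives a 20-fold higher number from compound 2 to compound 3 (1.30 log units; beyond the scatter). The step of a 1.3-fold lower number from compound 1 to compound 3 (0.12 log units; within the scatter) shows that ((2-aminoethyl)sulfonyl)amino and (methanesulfonamido)methyl on an aromatic carbon cannot be told apart here, so among these compounds the low number belongs only to the vinyl sulfonamide, compound 2. No measurement is available that explains either step.

The compounds shown leave open whether the rise follows from the departure of the vinyl double bond or from the arrival of the nitrogen in 2-aminoethyl. An ethyl group on the same sulfonyl sulfur would separate these two readings, and a longer chain ending in an amine would test the reach of that nitrogen.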